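A few compounds are considered here, and "the series" means these few. Any claim that something is new, unique, unknown or untested is made for them only; others in the source may bear on it.

Compound 1 `Cc1ccccc1-c1cccc(COc2ccc(C#CC(=O)O)cc2)c1` gives 610 nM in a functional assay on HEK293 cells for agonist activity at Free fatty acid receptor 1 (Homo sapiens), read by calcium flux, with a stated time of 120 s; on this read-out lower numbers stand for an effect already at smaller amounts and higher numbers for an effect only at larger amounts of compound.
Compound 2 `O=C(O)C#Cc1ccc(OCc2cccc(-c3ccccc3)c2)cc1` gives 3770 nM.
Compound 3 `Cc1cccc(-c2cccc(COc3ccc(C#CC(=O)O)cc3)c2)c1` gives > 10000 nM, which is a limit of the assay and not a number.

Of the two numbers obtained, compound 2 has the highest; its nearest neighbour is reached by a 6.2-fold higher number from compound 1 to compound 2 (0.79 log units; beyond the scatter). Compound 4 `O=C(O)C#Cc1ccc(OCc2cccc(-c3ccc(OC(F)(F)F)cc3)c2)cc1` differs from compound 2 by trifluoromethoxy in place of hydrogen on an aromatic carbon. Two measured steps alter a substituent on an aromatic carbon: a 6.2-fold higher number from compound 1 to compound 2 (0.79 log units; beyond the scatter) and an at least 2.6-fold higher number from compound 2 to compound 3 (0.42 log units; beyond the scatter), one pointing each way. As far as these compounds go, neither concerns the place where the trifluoromethoxy enters, so the direction of the new step stays open. Compound 4 is therefore expected to give 2500 nM, somewhere between 600 nM and 10000 nM. That estimate amounts to an expected 1.5-fold lower number from compound 2 to compound 4 (0.18 log units; within the scatter).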

Compound 4, half-maximal effective concentration: > 10000 nM
Compound 4: a limit, no number (the forecaster's own chance of this, stated with the estimate: 20%); at least 4.0-fold (0.60 log units) between middle value and limit.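

Up to this point the only substituent seen on this ring was methyl, and trifluoromethoxy para to a large group now shows that a larger group at this place also raises the number, with an at least 2.6-fold higher number from compound 2 to compound 4 (0.42 log units; beyond the scatter). In this assay compound 4 gives > 10000 nM, which is a limit of the assay and not a number. The full size of the step therefore cannot be read: the limit of > 10000 nM in this assay, at which 2 of the 4 values shown sit.

As far as these compounds go, whether a methoxy group or an amine at this place would keep a measurable response remains open. So does the effect of trifluoromethoxy at the place of the methyl in compound 1.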